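Hydroxy removal in a nitro-substituted catechol series: tolerability notes

The source may hold more compounds than are shown below. What is called first, only, known or untested is meant among the compounds shown, and "the series" means these compounds.

Compound 1 `CSc1nc2n(n1)C(c1ccc(O)c(O)c1)C([N+](=O)[O-])=NN2` and compound 3 `CSc1nc2n(n1)C(c1ccc(O)c(O)c1O)C([N+](=O)[O-])=NN2` share one core; compound 2 `O=[N+]([O-])C1=CNc2ncnn2C1c1ccc(O)c(O)c1O` is built on another. In an ADME assay on MDCK cells (Canis lupus familiaris) for cytotoxicity (a higher number here means that more compound is tolerated, a lower number that less compound is tolerated), compound 1 gives 362000 nM, compound 3 gives 196000 nM and compound 2 gives 405000 nM. The step of a 1.8-fold higher number from compound 3 to compound 1 (0.27 log units; within the scatter) is hydrogen in place of hydroxy on an aromatic carbon. How the cores of compound 2 and compound 3 differ is not broken down here; their values lie beyond the scatter of each other, whereas compound 2 and compound 1 lie within it. Compound 4 `O=[N+]([O-])C1=CNc2ncnn2C1c1ccc(O)cc1O` is not yet measured and carries hydrogen in place of hydroxy on an aromatic carbon. This is the same kind of change as that from compound 3 to compound 1, but the surroundings differ: here the carbon is ortho to two hydroxy groups and meta to a large group, there it is ortho to a hydroxy group, ortho to a large group and meta to a hydroxy group. The expectation rests on the step of a 1.8-fold higher number from compound 3 to compound 1 (0.27 log units; within the scatter), which lay within the scatter. In this assay compound 4 is expected near 500000 nM, a step of a 1.2-fold higher number from compound 2 to compound 4 (0.09 log units; within the scatter). The estimated range for compound 4 runs from 250000 nM to 1000000 nM.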

Compound 4, half-maximal cytotoxic concentration: > 1080000 nM
Compound 4 was reported as a limit; the forecaster's own chance of this, stated with the estimate: 20%; middle value at least 2.1-fold (0.33 log units) from the limit.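

In this assay, compound 4 gives > 1080000 nM, which is a limit of the assay and not a number. Going by these compounds, on the core of compound 2, hydrogen in place of hydroxy on an aromatic carbon gives an at least 2.6-fold higher number from compound 2 to compound 4 (0.42 log units; beyond the scatter), so this step can be read as lying beyond the scatter, although its full size stays unknown. The data do not show that the change carries over from one core to the other with the same size, and the carbon's surroundings also differ between the two cases: the same change on two cores in this assay, a 1.8-fold higher number (0.27 log units; within the scatter) from compound 3 to compound 1 and an at least 2.6-fold higher number (0.42 log units; beyond the scatter) from compound 2 to compound 4; the limit leaves it open whether they differ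

The compounds shown leave open whether a methoxy group or a fluorine atom in the same place would read like hydrogen or like hydroxy. They also leave open how either core would read with a nitrile or a carboxylic acid in place of the nitro group.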